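This account rests on a few compounds, and the source may have more. Where it says the series, first, only, none or still open, it means among the compounds named here.

Going by the values given here, compound 1 `O=C(CCN1CCN(c2ccccc2)CC1)N1CCN(c2ccccc2)CC1` gives 26.2 nM in an assay on cells for displacement of a labelled ligand from 5-hydroxytryptamine receptor 7 (Homo sapiens), read by scintillation counting, with a stated time of 30 min (on this read-out higher numbers stand for weaker inhibition and lower numbers for stronger inhibition), the lowest of the two numbers measured so far. Compound 2 `O=C(CCCCN1CCN(c2ccccc2)CC1)N1CCN(c2ccccc2)CC1`, which carries a longer chain between the two ring systems, gives 197 nM in this assay. Compound 3 `O=C(CCN1CCN(c2cccc(Cl)c2)CC1)N1CCN(c2ccccc2)CC1` has not yet been measured; it differs from compound 1 by chloro in place of hydrogen on an aromatic carbon. Among the compounds with values here, no measured pair shows this change, so its size is an expectation only: a small step, within the usual scatter or slightly towards stronger inhibition. For compound 3 the estimate in this assay is 15 nM, with a range from 5 nM to 50 nM, an expected step of a 1.7-fold lower number from compound 1 to compound 3 (0.24 log units; within the scatter).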

Compound 3, inhibition constant: 32.7 nM
The estimate for compound 3 lay 2.2-fold (0.34 log units) below the measured number, within the range that was stated.
By their numbers in this assay, from the lowest: compounds 1 and 3 (each within the scatter of the next); then compound 2.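

In this assay chloro in place of hydrogen on this aromatic carbon, meta to a large group, gives a 1.2-fold higher number from compound 1 to compound 3 (0.10 log units; within the scatter) and so leaves the reading unchanged within the scatter. Going by these compounds alone, this position therefore takes this one added heavy atom without a step beyond the scatter, something the earlier compounds, which differ only in chain length, could not show. Nothing available explains this result.

On these data alone, whether a larger group here, such as methoxy or an amine, would also leave the number in place remains open. So does whether chloro elsewhere on this ring, or on the longer chain compound 2, would behave the same way.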